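This account rests on a few compounds, and the source may have more. Where it says the series, first, only, none or still open, it means among the compounds named here.

The compounds measured so far:
compound 1 `CC1CCN(C2CCN(S(=O)(=O)c3cccc(Cl)c3)CC2)CC1` — in an ADME assay on HCT-116 cells (Homo sapiens) for cytotoxicity, read by CellTiter-Glo, with a stated time of 72 h (on this read-out higher numbers stand for weaker inhibition and lower numbers for stronger inhibition), compound 1 gives a limit, > 5000 nM
compound 2 `CC1CCN(C2CCN(S(=O)(=O)c3cccc(-c4ccccc4C(F)(F)F)c3)CC2)CC1` — in this assay compound 2 gives a limit, > 5000 nM
compound 3 `Cc1cc(C)cc(-c2cccc(S(=O)(=O)N3CCC(N4CCC(C)CC4)CC3)c2)c1` — in this assay compound 3 gives a limit, > 5000 nM

Compound 1 stands on a limit of this assay, not on a number, and so do the two other measured compounds; all three values shown sit at the limit of > 5000 nM in this assay, at which 3 of the 3 values shown sit. The unmeasured compound 4 `CC1CCN(C2CCN(S(=O)(=O)c3ccc(Cl)cc3Cl)CC2)CC1` differs from compound 1 in one place: 2,4-dichlorophenyl in place of 3-chlorophenyl on a sulfonyl sulfur. Within the data shown here, no measured step bears directly on this change, and none of the measured steps can be read in size at all: a step that the two limits leave unreadable from compound 1 to compound 2, a step that the two limits leave unreadable from compound 1 to compound 3, a step that the two limits leave unreadable from compound 2 to compound 3. Because every value sits at the limit of > 5000 nM in this assay, at which 3 of the 3 values shown sit, no direction or size of step can be drawn from the measured compounds for the change from compound 1 to compound 4. With all three measured compounds at a limit, compound 4 is expected to give a limit as well in this assay, so the step from compound 1 is estimated as a step that the limit leaves unreadable from compound 1 to compound 4, which is no step beyond the scatter. Compound 4 is therefore estimated at 8000 nM, within 4000 nM to 20000 nM.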

Compound 4, half-maximal inhibitory concentration: > 5000 nM
Compound 4 gave a limit, no number; the forecaster's own chance of this, stated with the estimate: 85%; the middle value is on the limit's open side.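

Compound 4 gives a limit in this assay, as compound 1 does, so no new step can be read from this result: the limit of > 5000 nM in this assay, at which 4 of the 4 values shown sit.

The compounds shown leave open what number any of the four would give in this assay, and whether 2,4-dichlorophenyl in place of 3-chlorophenyl changes the read-out at all.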